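The source may report more compounds than this note shows. Statements on the series, on what has been measured and on what is new or still open speak of the compounds shown alone.

Compound 1 `Cc1ccc(-c2cc(-c3ccoc3)cc(-c3ccc(Cl)s3)n2)cc1` is one of three measured compounds that share a core. In a functional assay on MCF7 cells (Homo sapiens) for cytotoxicity, read by ELISA, with a stated time of 4 days (a higher number here means a weaker inhibitor, a lower number a stronger inhibitor), compound 1 gives 5340 nM, compound 2 `Clc1cccc(-c2cc(-c3ccoc3)cc(-c3ccc(Cl)s3)n2)c1` gives 2920 nM and compound 3 `Clc1ccc(-c2cc(-c3ccoc3)cc(-c3ccccn3)n2)s1` gives 3360 nM. Compound 1 stands level with the other two, since its distance to each lies within the usual scatter of repeated measurements.

Compound 4 `Cc1ccc(-c2cc(-c3ccc(Cl)o3)cc(-c3ccc(Cl)s3)n2)cc1` differs from compound 1 in one place, with 5-chlorofuran-2-yl in place of furan-3-yl on an aromatic carbon opposite the ring nitrogen: 5-chlorofuran-2-yl in place of furan-3-yl on an aromatic carbon.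

The measured steps bear on this change only indirectly. Replacing 4-methylphenyl with 3-chlorophenyl gives a 1.8-fold lower number from compound 1 to compound 2 (0.26 log units; within the scatter), replacing it with pyridin-2-yl gives a 1.6-fold lower number from compound 1 to compound 3 (0.20 log units; within the scatter), and exchanging those two new groups gives a 1.2-fold higher number from compound 2 to compound 3 (0.06 log units; within the scatter). All three lie within the scatter, yet none of them touches the furan-3-yl group, so the new group has no direct measurement behind it.

As far as these compounds go, with so little to go on, no step beyond the scatter is expected in this assay, and the direction remains open. The expected step is small, a 1.3-fold lower number from compound 1 to compound 4 (0.13 log units; within the scatter). For compound 4 the estimated value is 4000 nM, with an expected range from 1500 nM to 11000 nM.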

Compound 4, half-maximal inhibitory concentration: 3040 nM
Beside the measured number, compound 4's estimate is 1.3-fold (0.12 log units) above it; the range from low to high includes it.
By their numbers in this assay, from the lowest: compounds 2, 4, 3 and 1 (each within the scatter of the next).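

In this assay, the step at the aromatic carbon opposite the ring nitrogen is a 1.8-fold lower number from compound 1 to compound 4 (0.24 log units; within the scatter), and it is the first step shown at this position, since the earlier steps all concerned the 4-methylphenyl group. Compound 4 therefore stands level with compound 1, so the furan-3-yl group can give way to 5-chlorofuran-2-yl, a ring that also carries a chlorine and is joined to the core through a different furan carbon, without a step beyond the usual scatter in this cytotoxicity read-out. No supporting data are available to explain this result, and a single step that alters both the chlorine and the point of attachment cannot show what each contributes alone.

As far as these compounds go, it remains open whether furan-2-yl without the chlorine would stand level with these two compounds, and whether the same exchange would also give a step within the scatter alongside the 3-chlorophenyl group of compound 2 or the pyridin-2-yl group of compound 3. From the compounds shown here alone, it is also open whether a quite different group at this position, such as an amine, a carboxylic acid or a longer chain, would produce a step beyond the scatter.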